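Working notes: bromo in place of fluoro, second instance

The source may hold more compounds than are shown below. What is called first, only, known or untested is meant among the compounds shown, and "the series" means these compounds.

Measured so far:
compound 1 `O=C(NS(=O)(=O)c1ccc(F)cc1)c1cncc(Br)c1`, which in a functional assay on MCF7 cells (Homo sapiens) for antiproliferative activity, read by MTT assay, with a stated time of 48 h (on this read-out higher numbers stand for weaker inhibition and lower numbers for stronger inhibition), gives 980 nM
compound 2 `O=C(NS(=O)(=O)c1ccc(Br)cc1)c1cncc(Br)c1`, which in this assay gives 340 nM
compound 3 `O=C(NS(=O)(=O)c1ccc(F)cc1)c1cccnc1Cl`, which in this assay gives 12500 nM

Compound 1 and compound 2 share a core and differ in one place: bromo in place of fluoro on an aromatic carbon. The step is a 2.9-fold lower number from compound 1 to compound 2 (0.46 log units; beyond the scatter). Compound 3 stands on another core; the difference between the two cores is not broken down here, and its number in this assay is the highest of the three.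

Compound 4 `O=C(NS(=O)(=O)c1ccc(Br)cc1)c1cccnc1Cl` is not yet measured. It relates to compound 3 by bromo in place of fluoro on an aromatic carbon, the same change as between compound 1 and compound 2, at the same place. Compound 4 is expected to show a 2.9-fold lower number from compound 3 to compound 4 (0.46 log units; beyond the scatter), a step of about the same size as a 2.9-fold lower number from compound 1 to compound 2 (0.46 log units; beyond the scatter), because this rests on compound 3 at 12500 nM as the starting point. Compound 4 is therefore estimated at 4300 nM, between 1500 nM and 12000 nM.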

Compound 4, half-maximal inhibitory concentration: 11400 nM
Compound 4: middle estimate off by 2.7-fold (0.42 log units), on the low side; the range from low to high includes it.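

In this assay, bromo in place of fluoro on the core of compound 3 gives a 1.1-fold lower number from compound 3 to compound 4 (0.04 log units; within the scatter). Set beside the earlier step, the result does not separate the two cores: the same change on two cores in this assay, a 2.9-fold lower number (0.46 log units; beyond the scatter) from compound 1 to compound 2 and a 1.1-fold lower number (0.04 log units; within the scatter) from compound 3 to compound 4, 2.6-fold (0.42 log units) apart, within the scatter of two such steps. The change is therefore not shown to behave differently from one core to the other, but with one step beyond the scatter, one within it and only two cores, an equal carry-over is not shown either.

The compounds shown leave open whether a group other than fluoro or bromo at this place, such as methoxy, a nitrile or an amine, would move the number on either core. Also open, as far as these compounds go, is whether the change would hold on a third core.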